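A Smaller Group on the Ring Carbon of Compound 3

The compounds below may be only part of what the source reports. "The series", "measured", "known", "first", "only" and "open" are said of these compounds alone.

Compound 3 `O=c1ccn([C@@H]2O[C@H](COP(=O)(O)OP(=O)(O)O)[C@@H](O)[C@H]2O)c(SCc2ccccc2)n1` was tested in an in vitro functional assay on 1321-N1 cells for agonist activity at P2Y purinoceptor 6 (Homo sapiens), read by scintillation proximity assay and inositol phosphate accumulation (on this read-out higher numbers stand for an effect only at larger amounts of compound and lower numbers for an effect already at smaller amounts), where compound 3 gives 6800 nM. Compound 2 `COc1nc(=O)ccn1[C@@H]1O[C@H](COP(=O)(O)OP(=O)(O)O)[C@@H](O)[C@H]1O` gives 1370 nM in this assay. For compound 1 `CCCSc1nc(=O)ccn1[C@@H]1O[C@H](COP(=O)(O)OP(=O)(O)O)[C@@H](O)[C@H]1O` the this assay reports only a limit of the assay, >= 100000 nM, not a number. Of the two actual numbers, compound 3 stands highest, and its nearest neighbour is compound 2, the step being a 5.0-fold higher number from compound 2 to compound 3 (0.70 log units; beyond the scatter). Compound 4 `CNc1nc(=O)ccn1[C@@H]1O[C@H](COP(=O)(O)OP(=O)(O)O)[C@@H](O)[C@H]1O` has not yet been measured; it differs from compound 3 in one place, (methylamino in place of benzylsulfanyl on an aromatic carbon). Within the data shown here, two measured steps bear on this change. The step of a 5.0-fold higher number from compound 2 to compound 3 (0.70 log units; beyond the scatter) shows that putting the large benzylsulfanyl group in place of the small methoxy group made the number worse. The step of an at least 72-fold lower number from compound 1 to compound 2 (1.86 log units; beyond the scatter) shows that a small methoxy group in place of the propylsulfanyl group made the number much better, moving it off the limit (the limit of >= 100000 nM in this assay, at which 1 of the 3 values shown sits). The change to compound 4 again replaces a large group with a small one, so a lower number, within about the size seen for compound 2, is expected. For compound 4 the expected step is a 2.7-fold lower number from compound 3 to compound 4 (0.43 log units; beyond the scatter). Compound 4 is estimated at 2500 nM, with a range from 600 nM to 10000 nM.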

Compound 4, half-maximal effective concentration: > 100000 nM
Compound 4 ended at the assay's limit; the forecaster's own chance of this, stated with the estimate: 10%; middle value at least 40-fold (1.60 log units) away from the limit.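

The small methoxy group of compound 2 and the larger groups of compound 1 and compound 3 could suggest that a small group works best on this aromatic carbon between two ring nitrogen atoms, but the small methylamino group goes against that reading in this assay, with an at least 14-fold higher number from compound 3 to compound 4 (1.16 log units; beyond the scatter) and, with a small group on both sides, an at least 72-fold higher number from compound 2 to compound 4 (1.86 log units; beyond the scatter). Size alone therefore does not order the compounds shown, and compound 3 also goes against a simple rule of small over large, with an at least 14-fold lower number from compound 1 to compound 3 (1.16 log units; beyond the scatter). Compound 4 sits at a limit of the assay, not at an actual number: the limit of > 100000 nM in this assay, at which 1 of the 4 values shown sits.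

Compound 1 also sits at a limit, so its step to compound 4 cannot be read: the limit of >= 100000 nM in this assay, at which 1 of the 4 values shown sits. The compounds shown leave open whether the poor result belongs to methylamino alone or extends to other nitrogen groups on this carbon, such as a plain amine, dimethylamino or ethylamino, and an ethoxy group would show whether the favourable methoxy result extends to a longer chain joined through oxygen.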